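Working notes: from compound 3 to compound 4

A few compounds are considered here, and "the series" means these few. Any claim that something is new, unique, unknown or untested is made for them only; others in the source may bear on it.

The series is read in a functional assay on MDA-MB-231 cells (Homo sapiens) for inhibition, read by MTT assay, with a stated time of 72 h; on this read-out higher numbers stand for weaker inhibition and lower numbers for stronger inhibition. Going by the values given here, compound 1 `O=C(CSc1nc(Nc2ccccc2)c2ccccc2n1)Nc1ccccc1Br` gives 14100 nM and compound 2 `CCc1ccc(NC(=O)CSc2nc(Nc3ccccc3)c3ccccc3n2)cc1` gives 33900 nM; the one measured step, a 2.4-fold higher number from compound 1 to compound 2 (0.38 log units; beyond the scatter), sits on an amide-type nitrogen. Compound 3 `C=CC(=O)Nc1cccc(NC(=O)CSc2nc(Nc3ccccc3Br)c3ccccc3n2)c1` gives 15200 nM, the second highest of the three numbers: against compound 1 it lies within the scatter, while compound 2 stands beyond the scatter with the higher number.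

Compound 4 `C=CC(=O)Nc1cccc(NC(=O)CSc2nc(Nc3cc(OC)c(OC)c(OC)c3)c3ccccc3n2)c1` differs from compound 3 in one place: 3,4,5-trimethoxyphenyl in place of 2-bromophenyl on a nitrogen on an aromatic ring. Among the compounds with values here, no measured step touches a nitrogen on an aromatic ring; the only step available lies on the amide-type nitrogen and was modest. The three numbers therefore give no ground for a move beyond the scatter in this assay in either direction, and the range has to stay wide. Compound 4 is expected to give 15000 nM, with a range from 5000 nM to 45000 nM. For compound 4 the step of a 1.0-fold lower number from compound 3 to compound 4 (0.01 log units; within the scatter) is expected to fall within the scatter.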

Compound 4, half-maximal inhibitory concentration: > 50000 nM
Compound 4: no number, only a limit; the forecaster's own chance of this, stated with the estimate: 10%; middle value at least 3.3-fold (0.52 log units) away from the limit.
By their numbers in this assay, from the lowest: compounds 1 and 3 (each within the scatter of the next); then compound 2. At a limit, above all of these: compound 4.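

In this assay, the nitrogen on an aromatic ring is now shown to be sensitive to its substituent: 3,4,5-trimethoxyphenyl in place of 2-bromophenyl gives an at least 3.2-fold higher number from compound 3 to compound 4 (0.51 log units; beyond the scatter). Going by these compounds alone, the only earlier step lay on the amide-type nitrogen, so this is the first evidence that a change at this second place also moves the read-out beyond the scatter. The reading for compound 4 is a limit of the assay and not a number, which leaves the true size of the step unknown: the limit of > 50000 nM in this assay, at which 1 of the 4 values shown sits.

Only these two groups can be compared at this nitrogen with the rest of the structure held constant, so the change cannot be assigned to the departing bromine or to the entering methoxy groups. On these data alone, whether a single methoxy group or an amine on that phenyl would keep the read-out near that of compound 3 remains open.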